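This account rests on a few compounds, and the source may have more. Where it says the series, first, only, none or still open, it means among the compounds named here.

Compound 1 `CC1CC(=O)c2s/c(=N/c3ccccc3)oc2C1` is the only one of the three measured compounds that gives a number: in a functional assay on MDA-MB-231 cells (Homo sapiens) for antiproliferative activity, read by sulforhodamine B assay (a lower number here means a stronger inhibitor of growth, a higher number a weaker inhibitor of growth), compound 1 gives 2310 nM. Compound 2 `CC1(C)CC(=O)c2s/c(=N/c3c(Cl)cc(Cl)cc3Cl)oc2C1` reaches only > 30000 nM in this assay, which is a limit of the assay and not a number. Compound 3 `CC1CC(=O)c2s/c(=N/c3c(Cl)cc(Cl)cc3Cl)oc2C1` likewise gives only a limit in this assay, > 30000 nM. Because the limit of > 30000 nM in this assay, at which 2 of the 3 values shown sit, stands in place of a number for both, the step that the two limits leave unreadable from compound 2 to compound 3 cannot be read in size, and compound 3 can be placed only at that limit, not at a number of its own. Compound 1 and compound 3 differ in more than one place, so their two values are simply shown side by side without a step between them.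

Compound 4 `CC(C)C1CC(=O)c2s/c(=N/c3c(Cl)cc(Cl)cc3Cl)oc2C1` differs from compound 3 in one place: isopropyl in place of methyl on a saturated ring carbon. For the measured compounds named here, no measured step shares this change, and the one step that touches the same saturated ring carbon is itself unreadable, so nothing measured points in either direction. Compound 4 is therefore expected to stay at the limit as well, estimated at 30000 nM with a range from 10000 nM to 100000 nM. The step of a number no higher from compound 3 to compound 4 (the limit leaves the size open) is expected to be no more than the scatter, if it can be read at all.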

Compound 4, concentration for 50% growth inhibition: > 30000 nM
Compound 4: no number, only a limit; the forecaster's own chance of this, stated with the estimate: 75%; the middle value lies on the limit itself.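

No new step can be read from compound 3 to compound 4 in this assay, because both compounds give only a limit and not a number: the limit of > 30000 nM in this assay, at which 3 of the 4 values shown sit.

The compounds shown leave open whether changing the group on the saturated ring carbon has any effect on growth inhibition.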